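Stripping the Pyridine Bare: From Compound 3 to Compound 4

The compounds below may be only part of what the source reports. "The series", "measured", "known", "first", "only" and "open" are said of these compounds alone.

Measured so far in a functional assay on the whole organism (strain Sprague-Dawley) for inhibition, with Rattus norvegicus as the target, read by paw edema, with a stated time of 180 min, at a dose of 10 mg/kg by the oral route; on this read-out higher numbers stand for a stronger effect at the one dose given and lower numbers for a weaker effect:
compound 1 `COc1ccnc(CNc2ccc3c(c2)nc(C)n3C[C@@H](O)[C@H]2O[C@H](O)[C@@H](O)[C@H]2O)c1OC` gives 41%
compound 2 `COc1ccnc(CNc2ccc3c(c2)nc(C)n3C[C@@H](O)[C@H]2O[C@H](O)[C@@H](O)[C@H]2O)c1C` gives 22%
compound 3 `COc1c(C)cnc(CNc2ccc3c(c2)nc(C)n3C[C@@H](O)[C@H]2O[C@H](O)[C@@H](O)[C@H]2O)c1C` gives 36%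

On these numbers compound 3 sits between the other two: its distance from compound 1 is a number 5 percentage points lower from compound 1 to compound 3 (within the scatter), which the repeated-measurement scatter covers, while its rise over compound 2 is a number 14 percentage points higher from compound 2 to compound 3 (beyond the scatter), beyond that scatter. Compound 4 `Cc1nc2cc(NCc3ccccn3)ccc2n1C[C@@H](O)[C@H]1O[C@H](O)[C@@H](O)[C@H]1O` is the next step; it differs from compound 3 in this way: pyridin-2-yl in place of 4-methoxy-3,5-dimethylpyridin-2-yl on a saturated chain carbon bound to a nitrogen on an aromatic ring. For the measured compounds named here, two measured steps bear on it. Swapping methyl for methoxy gave a number 19 percentage points lower from compound 1 to compound 2 (beyond the scatter), a loss, and adding a methyl where hydrogen stood gave a number 14 percentage points higher from compound 2 to compound 3 (beyond the scatter), a gain. Compound 4 gives up the methoxy and both methyls at once, so in this assay a drop is expected, estimated at a number 16 percentage points lower from compound 3 to compound 4 (beyond the scatter). With that, compound 4 is expected to show 20%, with a likely range from 5% to 38%, though three compounds give only a rough footing for this guess.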

Compound 4, a percentage reported as inhibition, in the whole organism at one dose (the size of the read-out at that dose, not a potency): 8%
The estimate for compound 4 lay 12 percentage points above the measured number; the measured number falls inside the stated range.
By their numbers in this assay, from the lowest: compound 4; then compound 2; then compounds 3 and 1 (each within the scatter of the next).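

In this assay, stripping the pyridine down to plain pyridin-2-yl on the saturated chain carbon gives a number 28 percentage points lower from compound 3 to compound 4 (beyond the scatter), so the bare ring does not hold on to the effect seen with the substituted rings. The loss appears against each substituted ring: the change from 4-methoxy-3-methylpyridin-2-yl gives a number 14 percentage points lower from compound 2 to compound 4 (beyond the scatter), and the change from 3,4-dimethoxypyridin-2-yl gives a number 33 percentage points lower from compound 1 to compound 4 (beyond the scatter). Compound 4 therefore stands as the weakest of the four, which shows that the groups on this pyridine matter at this dose, a point the swaps among substituted rings could not show.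

Going by these compounds, compound 4 loses its groups together, so how much each one contributes stays open, as does how a pyridine carrying a lone methoxy, a chlorine or an amine would read. Nothing available explains why the effect falls with this change.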